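A few compounds are considered here, and "the series" means these few. Any claim that something is new, unique, unknown or untested is made for them only; others in the source may bear on it.

In a functional assay on KB cells (Homo sapiens) for cytotoxicity, read by MTT assay, with a stated time of 72 h (a higher number here means a weaker inhibitor, a lower number a stronger inhibitor), compound 1 `COc1cc2ncnc(NNC(=S)NC(=O)c3ccccc3C)c2cc1OC` gives 11400 nM. Compound 2 `COc1cc2ncnc(NNC(=S)NC(=O)c3ccccc3)c2cc1OC` has hydrogen in place of methyl on an aromatic carbon, and in this assay compound 2 gives 3770 nM, which is a 3.0-fold lower number from compound 1 to compound 2 (0.48 log units; beyond the scatter). Compound 3 `COc1ccccc1C(=O)NC(=S)NNc1ncnc2ccccc12` carries a methoxy group on that same benzoyl ring and lacks the two methoxy groups on the shared core of compounds 1 and 2. In this assay compound 3 gives > 50000 nM, which is a limit of the assay rather than a measured number (the limit of > 50000 nM in this assay, at which 1 of the 3 values shown sits). Compound 3 therefore stands at the weak end of everything measured here, with no exact value known.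

Compound 4 `O=C(NC(=S)NNc1ncnc2ccccc12)c1ccccc1Cl` differs from compound 3 in one place: chloro in place of methoxy on an aromatic carbon. For the measured compounds named here, the only measured step on this series is the one from compound 1 to compound 2, a 3.0-fold lower number from compound 1 to compound 2 (0.48 log units; beyond the scatter), and it concerns a different group on a differently substituted core, so it offers a scale rather than a direction. A change of that modest size starting from a limit would most likely leave compound 4 at or near that same limit. The expected step from compound 3 to compound 4 is an at least 1.2-fold lower number from compound 3 to compound 4 (0.09 log units; that floor lies within the scatter), and compound 4 is estimated at 40000 nM, with a range from 10000 nM to 150000 nM.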

Compound 4, half-maximal inhibitory concentration: 7710 nM
For compound 4 the middle estimate is 5.2-fold (0.72 log units) above the measured one, outside the stated range (below it).
By their numbers in this assay, from the lowest: compound 2; then compounds 4 and 1 (each within the scatter of the next). At a limit, above all of these: compound 3.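

The swap from 2-methoxyphenyl to 2-chlorophenyl shows that, on the core of compound 3, this position decides whether a number can be read at all: in this assay it gives an at least 6.4-fold lower number from compound 3 to compound 4 (0.81 log units; beyond the scatter). The earlier compounds shown here showed only a change on the shared core of compounds 1 and 2, and they gave no measured number for the core without its two methoxy groups. Compound 3 sits at a limit of the assay rather than at a measured number, so this step is only a floor and its true size stays unknown: the limit of > 50000 nM in this assay, at which 1 of the 4 values shown sits.

Methoxy counts one hydrogen-bond acceptor and chloro none, but these compounds cannot show whether that difference, or any other, lies behind the change. Still open, from the compounds shown here alone, is whether the same swap would act in the same way on the shared core of compounds 1 and 2, and how a bromo group, an amine or plain hydrogen at this position would compare with chloro on the core of compound 4.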